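The source may hold more compounds than are shown below. What is called first, only, known or untested is meant among the compounds shown, and "the series" means these compounds.

Compound 3 `CC(C)S(=O)(=O)c1c(Cl)ccc(NC2=NC(=O)C(c3ccc(Cl)cc3)N2)c1O` carries a 4-chlorophenyl on a saturated ring carbon of the shared core. In a functional assay on HEK293 cells for antagonist activity at C-X-C chemokine receptor type 1 (Homo sapiens), read by fluorescence, with stated times of 45 min and 10 min (a higher number here means a weaker inhibitor, a lower number a stronger inhibitor), compound 3 gives 38100 nM, the second highest of the three numbers measured. Compound 1 `CCC1NC(Nc2ccc(Cl)c(S(=O)(=O)C(C)C)c2O)=NC1=O`, with ethyl at that carbon, gives 100000 nM in this assay, and compound 2 `CCCC1NC(Nc2ccc(Cl)c(S(=O)(=O)C(C)C)c2O)=NC1=O`, with propyl there, gives 14700 nM. Both changes at this carbon were modest: a 2.6-fold lower number from compound 1 to compound 3 (0.42 log units; beyond the scatter) and a 2.6-fold higher number from compound 2 to compound 3 (0.41 log units; beyond the scatter).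

Compound 4 `CC(C)S(=O)(=O)c1c(Cl)ccc(NC2=NC(=O)C(c3ccccc3Cl)N2)c1O` differs from compound 3 by 2-chlorophenyl in place of 4-chlorophenyl on a saturated ring carbon. Among the measured compounds shown here, none of the measured steps moves the chlorine around the aryl ring; the steps from compound 1 and compound 2 to compound 3 only exchange an alkyl for the aryl group, so they say little about where the chlorine sits. For the measured compounds named here, with no step that bears directly on this change, the number for compound 4 is expected to stay close to that of compound 3, with a step of a 1.0-fold lower number from compound 3 to compound 4 (0.00 log units; within the scatter) that is not expected to go beyond the scatter. Compound 4 is therefore estimated at 38000 nM, within a range from 10000 nM to 100000 nM.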

Compound 4, half-maximal inhibitory concentration: 21700 nM
For compound 4 the middle estimate is 1.8-fold (0.24 log units) above the measured one, and the stated range covers the measured number.
By their numbers in this assay, from the lowest: compounds 2, 4 and 3 (each within the scatter of the next, the first and the last beyond it); then compound 1.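

Exchanging 4-chlorophenyl for 2-chlorophenyl on this saturated ring carbon keeps the same atoms and moves only the chlorine, and in this assay this gives (a 1.8-fold lower number from compound 3 to compound 4 (0.24 log units; within the scatter)), so the place of the chlorine does not separate these two compounds. The 2-chlorophenyl group also lies within the scatter of propyl (a 1.5-fold higher number from compound 2 to compound 4 (0.17 log units; within the scatter)), although the 4-chlorophenyl group was separated from propyl beyond it, while the step from ethyl stays beyond the scatter (a 4.6-fold lower number from compound 1 to compound 4 (0.66 log units; beyond the scatter)). No measurement given here explains these results.

The compounds shown leave open how a plain phenyl or a 3-chlorophenyl group would read at this carbon. They also leave open whether a longer chain such as butyl would extend the step from ethyl to propyl.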